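The source may report more compounds than this note shows. Statements on the series, on what has been measured and on what is new or still open speak of the compounds shown alone.

Measured so far in a functional assay on A549 cells (Homo sapiens) for antiproliferative activity, read by MTT assay, with a stated time of 48 h; a higher number here means a weaker inhibitor of growth, a lower number a stronger inhibitor of growth:
compound 1 `CCOC(=O)N1N=C(c2cccc(OC)c2)CC1c1cc(OC)c(OC)c(OC)c1` gives 5920 nM
compound 2 `COc1cccc(C2=NN(C(=O)OCc3ccccc3)C(c3cc(OC)c(OC)c(OC)c3)C2)c1` gives > 10000 nM as a limit of the assay, not a number
compound 3 `CCOC(=O)N1N=C(c2ccc(OC)cc2)CC1c1cc(OC)c(OC)c(OC)c1` gives 4690 nM

Among the measured compounds shown here, compound 3 (4690 nM) lies within the scatter of compound 1 (5920 nM), the only other true number. Between them stands a 1.3-fold lower number from compound 1 to compound 3 (0.10 log units; within the scatter) for 4-methoxyphenyl in place of 3-methoxyphenyl.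

The next compound to read is compound 4 `COc1ccc(C2=NN(C(=O)OCc3ccccc3)C(c3cc(OC)c(OC)c(OC)c3)C2)cc1`, and its difference from compound 3 is phenyl in place of methyl on a saturated chain carbon bound to an oxygen next to a carbonyl group. In other words, ethoxycarbonyl gives way to benzyloxycarbonyl.

For the measured compounds named here, only one measured step makes the same replacement: an at least 1.6-fold higher number from compound 1 to compound 2 (0.22 log units; that floor lies within the scatter), seen on the 3-methoxyphenyl pair. That step is bounded on one side only, and its end point is the limit of > 10000 nM in this assay, at which 1 of the 3 values shown sits. The same swap on compound 3 is therefore expected to move the number upward, though the evidence for this is thin, and a report of only a limit for compound 4 is quite possible.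

In this assay the expected change is a 1.9-fold higher number from compound 3 to compound 4 (0.28 log units; within the scatter), resting on compound 2 and its step of an at least 1.6-fold higher number from compound 1 to compound 2 (0.22 log units; that floor lies within the scatter). For compound 4 the estimated value is 9000 nM, with an expected range from 4500 nM to 20000 nM.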

Compound 4, concentration for 50% growth inhibition: > 10000 nM
Compound 4 gave a limit, no number (the forecaster's own chance of this, stated with the estimate: 55%); middle value at least 1.1-fold (0.04 log units) from the limit.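

In this assay, the change from ethoxycarbonyl to benzyloxycarbonyl now gives a step that clears the scatter, on the core of compound 3: an at least 2.1-fold higher number from compound 3 to compound 4 (0.32 log units; beyond the scatter). The earlier pair gave only a floor within the scatter, whereas the upward direction is now seen on two cores, and neither benzyloxycarbonyl compound shown returns a true number: the same change on two cores in this assay, an at least 1.6-fold higher number (0.22 log units; that floor lies within the scatter) from compound 1 to compound 2 and an at least 2.1-fold higher number (0.32 log units; beyond the scatter) from compound 3 to compound 4; the limit leaves it open whether they differ. The step from compound 2 to compound 4 cannot be read, so any comparison of 4-methoxyphenyl with 3-methoxyphenyl rests on the ethoxycarbonyl pair alone, where the step lies within the scatter: the limit of > 10000 nM in this assay, at which 2 of the 4 values shown sit.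

The compounds shown leave open how large the change really is, and whether it follows the phenyl ring itself or simply a larger group on that saturated chain carbon. A propyl or butyl chain in place of ethyl would separate those two readings, while a methoxycarbonyl group would show whether a shorter chain moves the number in this assay at all.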